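Swapping Cyclohexyl for Chlorothiophene on the Shared Core

This account rests on a few compounds, and the source may have more. Where it says the series, first, only, none or still open, it means among the compounds named here.

In a functional assay on HCT-116 cells (Homo sapiens) for cytotoxicity, read by MTT assay, with a stated time of 48 h, in the presence of a further agent that is not named here (a higher number here means that more compound is needed for the effect, a lower number that less compound is needed), compound 1 (`CCCc1cc(NNC(=O)Nc2cc(Cl)nc(Cl)c2)nc2c1c(C)nn2C`) gives 72200 nM, compound 2 (`COc1ccc(-c2cc(NNC(=O)Nc3cc(Cl)nc(Cl)c3)nc3c2c(C)nn3C)cc1`) gives 82300 nM, and compound 3 (`Cc1nn(C)c2nc(NNC(=O)Nc3cc(Cl)nc(Cl)c3)cc(C3CCCCC3)c12`) gives 38000 nM. Compound 3 thus stands within the scatter of compound 1, as a 1.9-fold lower number from compound 1 to compound 3 (0.28 log units; within the scatter) shows, and only modestly apart from compound 2, as a 2.2-fold lower number from compound 2 to compound 3 (0.34 log units; beyond the scatter) shows. Compound 4 (`Cc1nn(C)c2nc(NNC(=O)Nc3cc(Cl)nc(Cl)c3)cc(-c3ccc(Cl)s3)c12`) has 5-chlorothiophen-2-yl in place of cyclohexyl on an aromatic carbon. All three measured steps change the group at this same place. Within the data shown here, the nearest precedent is the exchange between 4-methoxyphenyl and cyclohexyl, which gave a 2.2-fold lower number from compound 2 to compound 3 (0.34 log units; beyond the scatter). The exchange of propyl for 4-methoxyphenyl gave a 1.1-fold higher number from compound 1 to compound 2 (0.06 log units; within the scatter). Since no step among these three compounds is large, only a small rise in this assay is expected, probably none beyond the scatter. The estimated step is a 1.3-fold higher number from compound 3 to compound 4 (0.12 log units; within the scatter). For compound 4 the expected value is 50000 nM, with an estimated range of 22000 nM to 110000 nM.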

Compound 4, half-maximal effective concentration: 42100 nM
Compound 4: middle estimate off by 1.2-fold (0.07 log units), on the high side; measured number inside the range.
By their numbers in this assay, from the lowest: compounds 3, 4, 1 and 2 (each within the scatter of the next, the first and the last beyond it).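

In this assay, replacing cyclohexyl with 5-chlorothiophen-2-yl on this aromatic carbon, opposite the ring nitrogen, swaps a non-aromatic ring of carbon only for a five-membered aromatic ring with a hetero atom, yet the step stays within the scatter: a 1.1-fold higher number from compound 3 to compound 4 (0.04 log units; within the scatter). Compound 4 also lies within the scatter of the other two compounds, as shown by a 2.0-fold lower number from compound 2 to compound 4 (0.29 log units; within the scatter) and a 1.7-fold lower number from compound 1 to compound 4 (0.23 log units; within the scatter), whereas compound 3 lies beyond the scatter of compound 2. No measurement shown here offers an explanation for these small steps.

Going by these compounds, it remains open whether an amine, a carboxylic acid or a longer alkyl chain at this place would move the number beyond the scatter. On these data alone, all four compounds share everything outside this position, so the effect of changes elsewhere on the molecule also remains open.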